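Phthalimide thiocarbamates: cytotoxicity and a methylphenyl swap

The source may hold more compounds than are shown below. What is called first, only, known or untested is meant among the compounds shown, and "the series" means these compounds.

Compound 1 `O=C1c2ccccc2C(=O)N1CCOC(=S)N(C(=O)c1ccccc1[N+](=O)[O-])c1ccc(Cl)cc1` is the reference point of the series. In an ADME assay on MT4 cells (Homo sapiens) for cytotoxicity, read by MTT assay (on this read-out lower numbers stand for higher toxicity in this test and higher numbers for lower toxicity in this test), compound 1 gives 21000 nM. Compound 2 `Cc1cccc(C(=O)N(C(=S)OCCN2C(=O)c3ccccc3C2=O)c2ccc(Cl)cc2)c1` carries the change (3-methylphenyl in place of 2-nitrophenyl on a carbonyl carbon); in this assay compound 2 gives 58000 nM, a step of a 2.8-fold higher number from compound 1 to compound 2 (0.44 log units; beyond the scatter). Compound 3 `Cc1ccc(N(C(=O)c2ccccc2[N+](=O)[O-])C(=S)OCCN2C(=O)c3ccccc3C2=O)cc1` differs from compound 1 by methyl in place of chloro on an aromatic carbon; in this assay compound 3 gives 100000 nM, a step of a 4.8-fold higher number from compound 1 to compound 3 (0.68 log units; beyond the scatter).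

Compound 4 `Cc1ccc(N(C(=O)c2cccc(C)c2)C(=S)OCCN2C(=O)c3ccccc3C2=O)cc1` is not yet measured. It differs from compound 3 by 3-methylphenyl in place of 2-nitrophenyl on a carbonyl carbon, the same change as from compound 1 to compound 2, on a core that differs by methyl in place of chloro on an aromatic carbon. For the measured compounds named here, the step from compound 3 to compound 4 in this assay is expected to be about a 2.0-fold higher number from compound 3 to compound 4 (0.30 log units; within the scatter), resting on the single earlier step of a 2.8-fold higher number from compound 1 to compound 2 (0.44 log units; beyond the scatter). Compound 4 is therefore estimated at 200000 nM in this assay, with the caution that the value of compound 3 already sits high and a limit rather than a number may be returned.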

Compound 4, half-maximal cytotoxic concentration: > 100000 nM
Compound 4: no number, only a limit (the forecaster's own chance of this, stated with the estimate: 40%); the middle value lies beyond the limit too.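

In this assay compound 4 gives > 100000 nM, a limit of the assay and not a number. 3-methylphenyl in place of 2-nitrophenyl gives a number no lower from compound 3 to compound 4 (the limit leaves the size open), so the change shows no fall on the second core, but the data do not show that the earlier step carries over unchanged: the same change on two cores in this assay, a 2.8-fold higher number (0.44 log units; beyond the scatter) from compound 1 to compound 2 and a number no lower (the limit leaves the size open) from compound 3 to compound 4; the limit leaves it open whether they differ. Methyl in place of chloro gives an at least 1.7-fold higher number from compound 2 to compound 4 (0.23 log units; that floor lies within the scatter), and its comparison with the earlier step stays open as well: the same change on two cores in this assay, a 4.8-fold higher number (0.68 log units; beyond the scatter) from compound 1 to compound 3 and an at least 1.7-fold higher number (0.23 log units; that floor lies within the scatter) from compound 2 to compound 4; the limit leaves it open whether they differ.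

From the compounds shown here alone, it remains open how far compound 4 lies past the limit. The compounds shown also leave open what an amine or a carboxylic acid on that carbonyl carbon, in place of 3-methylphenyl, would do on either core.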